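This account rests on a few compounds, and the source may have more. Where it says the series, first, only, none or still open, it means among the compounds named here.

In a functional assay on HeLa cells (Homo sapiens) for antiproliferative activity, read by MTT assay, with a stated time of 72 h (on this read-out lower numbers stand for stronger inhibition and higher numbers for weaker inhibition), three compounds sharing one core have been measured. Compound 1 `O=C1O[C@H]([C@@H](O)Cn2cc(CCO)nn2)C(OCc2ccccc2)=C1OCc1ccccc1` gives 68800 nM, compound 2 `CCCCCc1ccc(-c2cn(C[C@H](O)[C@H]3OC(=O)C(OCc4ccccc4)=C3OCc3ccccc3)nn2)cc1` gives 8390 nM, and compound 3 `O=C1O[C@H]([C@@H](O)Cn2cc(CCCCl)nn2)C(OCc2ccccc2)=C1OCc1ccccc1` gives 36700 nM. Compound 3 thus stands second highest of the three, close to compound 1 and clearly apart from compound 2. Compound 4 `O=C1O[C@H]([C@@H](O)Cn2cc(-c3ccc(Br)cc3)nn2)C(OCc2ccccc2)=C1OCc1ccccc1` differs from compound 3 by 4-bromophenyl in place of 3-chloropropyl on an aromatic carbon. For the measured compounds named here, two measured steps bear on this: an 8.2-fold lower number from compound 1 to compound 2 (0.91 log units; beyond the scatter), and a 4.4-fold higher number from compound 2 to compound 3 (0.64 log units; beyond the scatter). Both show that an aryl group on that carbon goes with a lower number than a chain. Compound 4 is therefore expected to show a 2.4-fold lower number from compound 3 to compound 4 (0.39 log units; beyond the scatter), giving an estimated 15000 nM, with a likely range from 5000 nM to 40000 nM.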

Compound 4, half-maximal inhibitory concentration: 3910 nM
For compound 4 the middle estimate is 3.8-fold (0.58 log units) above the measured one; measured number outside the range, below it.
By their numbers in this assay, from the lowest: compound 4; then compound 2; then compounds 3 and 1 (each within the scatter of the next).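

The lower number with 4-pentylphenyl did not depend on the pentyl chain: 4-bromophenyl on this aromatic carbon also gives a lower number, with a 9.4-fold lower number from compound 3 to compound 4 (0.97 log units; beyond the scatter) and an 18-fold lower number from compound 1 to compound 4 (1.25 log units; beyond the scatter). What the phenyl ring itself carries also counts, since bromo in place of pentyl gives a 2.1-fold lower number from compound 2 to compound 4 (0.33 log units; beyond the scatter). Nothing measured here explains these differences. Still open, going by these compounds, is whether an unsubstituted phenyl, or a phenyl carrying an amine or a carboxylic acid in place of bromo, would keep this lower number.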